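Changing the Amine Group and the Maximal Response

A few compounds are considered here, and "the series" means these few. Any claim that something is new, unique, unknown or untested is made for them only; others in the source may bear on it.

Measured so far:
compound 1 `c1ccc2c(c1)CCC2NC1CCN(CCCc2c[nH]c3ccc(-n4cnnc4)cc23)CC1`: 68%
compound 2 `c1ccc(C2CCCCN2C2CCN(CCCc3c[nH]c4ccc(-n5cnnc5)cc34)CC2)cc1`: 65%

In a functional assay on CHO cells for activation of 5-hydroxytryptamine receptor 1D (Homo sapiens), read by GTPgammaS binding (on this read-out lower numbers stand for smaller maximal responses and higher numbers for larger maximal responses), compound 1 gives 68%. Compound 2 gives 65% in this assay, a gap that lies within the usual scatter, so compound 1 holds the higher of the two numbers only formally; the two compounds reach the same kind of maximal response. The unmeasured compound 3 `CN(Cc1ccsc1)C1CCN(CCCc2c[nH]c3ccc(-n4cnnc4)cc23)CC1` keeps the shared core of compound 1 and alters the group on a saturated ring carbon of the six-membered non-aromatic ring with 1 nitrogen: methyl((thiophen-3-yl)methyl)amino in place of (2,3-dihydro-1H-inden-1-yl)amino on a saturated ring carbon. Both measured compounds carry a ring-bearing amine at this position and give similar read-outs, which gives no basis for expecting a step beyond the scatter in either direction. The step of a number 3 percentage points lower from compound 1 to compound 3 (within the scatter) is therefore expected to be small. Compound 3 is estimated at 65%, within a range of 45% to 85%.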

Compound 3, largest response reached (reported as efficacy), in percent of the reference or control that the assay uses: 93%
Compound 3: middle estimate off by 28 percentage points, on the low side, and the stated range ends below it.
By their numbers in this assay, from the lowest: compounds 2 and 1 (each within the scatter of the next); then compound 3.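

The first two compounds gave similar read-outs, which made this position look as if it might tolerate changes without much effect on the maximal response. Compound 3 shows otherwise: methyl((thiophen-3-yl)methyl)amino in place of (2,3-dihydro-1H-inden-1-yl)amino gives a number 25 percentage points higher from compound 1 to compound 3 (beyond the scatter), so a ring-bearing amine on this saturated ring carbon does not fix the response at one level. Nothing available here explains the rise.

This single change replaces the ring system, adds a methyl group on the nitrogen and removes a hydrogen-bond donor all at once, so the shown compounds cannot assign the rise to any one of these. A (thiophen-3-yl)methylamino group without the methyl, or a benzyl(methyl)amino group with a phenyl ring in place of the thiophene, would pull these features apart.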